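The source may report more compounds than this note shows. Statements on the series, on what has been measured and on what is new or still open speak of the compounds shown alone.

Three compounds share one core and differ only in the aromatic group on a double-bonded chain carbon bound to a double-bonded ring carbon. In a functional assay on K562 cells (Homo sapiens) for inhibition, read by MTT assay, with a stated time of 72 h, tested at 10 uM (a lower number here means less inhibition, a higher number more inhibition at the concentration tested (going by the name of the read-out)), compound 1 `CCOC(=O)C1=C(Nc2ccccc2)S/C(=C\c2ccc(OC)cc2)C1=O` gives 9.6%, compound 2 `CCOC(=O)C1=C(Nc2ccccc2)S/C(=C\c2ccc(C(=O)O)cc2)C1=O` gives 27.5%, and compound 3 `CCOC(=O)C1=C(Nc2ccccc2)S/C(=C\c2cc[nH]c2)C1=O` gives 18.9%. Compound 3 stands second highest of the three, with both neighbours within the scatter: the change was a number 9.3 percentage points higher from compound 1 to compound 3 (within the scatter) and a number 8.6 percentage points lower from compound 2 to compound 3 (within the scatter). Compound 4 `CCOC(=O)C1=C(Nc2ccccc2)S/C(=C\c2cc3ccncc3[nH]2)C1=O` carries a group of 9 heavy atoms (7 carbon, 2 nitrogen; one five-membered aromatic ring with 1 hetero atom, one six-membered aromatic ring with 1 hetero atom) in place of a group of 5 heavy atoms (4 carbon, 1 nitrogen; one five-membered aromatic ring with 1 hetero atom), on a double-bonded chain carbon bound to a double-bonded ring carbon. The two swaps measured at this position stayed within the scatter, so no step beyond the scatter is expected here either, and the expected step is a number 3.1 percentage points higher from compound 3 to compound 4 (within the scatter). Compound 4 is therefore estimated to give 22% in this assay, with a range from 5% to 42%.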

Compound 4, a percentage reported as inhibition, at one concentration (the size of the read-out at that concentration, not a potency): 22.8%
Estimate against measurement, compound 4: 0.8 percentage points below; low and high end bracket the measured number.
By their numbers in this assay, from the lowest: compounds 1, 3, 4 and 2 (each within the scatter of the next, the first and the last beyond it).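

Enlarging the group at this position leaves the read-out in this assay close to that of the smaller 1H-pyrrol-3-yl compound (a number 3.9 percentage points higher from compound 3 to compound 4 (within the scatter)), so the added six-membered aromatic ring with 1 hetero atom brings no step beyond the scatter. The result also lies close to the carboxy compound (a number 4.7 percentage points lower from compound 2 to compound 4 (within the scatter)). Only the methoxy compound stands apart (a number 13.2 percentage points higher from compound 1 to compound 4 (beyond the scatter)), making compound 4 the second group to clear the scatter against it.

As far as these compounds go, what an amine or a longer chain on this aromatic group would give remains open. Nothing available here explains these differences.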